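Swapping 4-methoxyphenyl for pyridin-2-yl at the assay limit

This account rests on a few compounds, and the source may have more. Where it says the series, first, only, none or still open, it means among the compounds named here.

Measured in a functional assay on cells (Platelet, Homo sapiens) for inhibition; on this read-out lower numbers stand for stronger inhibition and higher numbers for weaker inhibition:
- Compound 1 `CCOC(=O)c1ccc(-c2nn(Cc3cccc(F)c3)c3ccccc23)cc1`: > 10000 nM (a limit)
- Compound 2 `CCOC(=O)c1ccc(-c2nn(Cc3cccc(OC)c3)c3ccccc23)cc1`: > 10000 nM (a limit)
- Compound 3 `CCOC(=O)c1ccc(-c2nn(Cc3ccc(OC)cc3)c3ccccc23)cc1`: > 10000 nM (a limit)

Compound 3 stands at > 10000 nM, which is a limit and not a number. Compound 4 `CCOC(=O)c1ccc(-c2nn(Cc3ccccn3)c3ccccc23)cc1` carries pyridin-2-yl in place of 4-methoxyphenyl on a saturated chain carbon bound to an aromatic nitrogen. The closest measured changes are a step that the two limits leave unreadable from compound 2 to compound 3 and a step that the two limits leave unreadable from compound 1 to compound 3, while a step that the two limits leave unreadable from compound 1 to compound 2 changes only the substituent on the aromatic carbon. None of these gives a size to carry over. Compound 4 is therefore expected to stay weak because of the limit of > 10000 nM in this assay, at which 3 of the 3 values shown sit. The expected outcome is a step that the limit leaves unreadable from compound 3 to compound 4, with no firm direction. For compound 4 the estimated value is 15000 nM, with an expected range from 6000 nM to 40000 nM.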

Compound 4, half-maximal inhibitory concentration: > 10000 nM
Compound 4: only a limit was reported; the forecaster's own chance of this, stated with the estimate: 75%; the middle value does not contradict the limit.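

In this assay, within the data shown here, compound 4 ends at a limit, as do compound 1, compound 2 and compound 3, so no step among them can be read. Going by these compounds, how strongly any of them inhibits, and whether the changed group matters, stays open.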